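This account rests on a few compounds, and the source may have more. Where it says the series, first, only, none or still open, it means among the compounds named here.

Two members of the series have been measured in an assay on isolated protein for inhibition of histone deacetylase 8 (Homo sapiens), with a stated time of 1 h; a lower number here means a stronger inhibitor, a higher number a weaker inhibitor. Compound 1 `O=C(COc1ccc2cc(/C=C3/SC(=O)NC3=O)ccc2c1)Nc1ccc(Br)cc1F` comes back as a limit of the measurement rather than a number: in this assay compound 1 gives > 50000 nM. Compound 2 `Cc1ccc(NC(=O)COc2ccc3cc(/C=C4/SC(=O)NC4=O)ccc3c2)cc1Cl` is likewise a limit, giving > 50000 nM in this assay. The step that the two limits leave unreadable from compound 1 to compound 2 cannot be read, since both values rest at the limit of > 50000 nM in this assay, at which 2 of the 2 values shown sit. Compound 1 therefore stands at the limit and nowhere within the measurable range.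

Compound 3 `O=C(COc1ccc2cc(/C=C3/SC(=O)NC3=O)ccc2c1)Nc1ccc(Br)cc1` differs from compound 1 by hydrogen in place of fluoro on an aromatic carbon, the same difference read one bond further out being 4-bromo-2-fluorophenyl to 4-bromophenyl. Going by the values given here, no measured step bears on this change, and the only step available is unreadable. Nothing points to a gain, so no step beyond the scatter is expected, the expected step being a step that the limit leaves unreadable from compound 1 to compound 3. Compound 3 is expected at 60000 nM, with a range of 20000 nM to 200000 nM, most likely reported again only as a limit.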

Compound 3, half-maximal inhibitory concentration: 16000 nM
The estimate for compound 3 lay 3.8-fold (0.57 log units) above the measured number; the measured number lies below the stated range.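

In this assay, hydrogen in place of fluoro on an aromatic carbon, ortho to a large group, gives an at least 3.1-fold lower number from compound 1 to compound 3 (0.49 log units; beyond the scatter) and yields the only value in the series shown that is not a limit. Going by these compounds alone, on the amide-type nitrogen, 4-bromophenyl in place of 3-chloro-4-methylphenyl gives an at least 3.1-fold lower number from compound 2 to compound 3 (0.49 log units; beyond the scatter) and so separates these two aryl groups for the first time. Both steps are minimum sizes, and the step between compound 1 and compound 2 cannot be read, because those compounds rest at a limit: the limit of > 50000 nM in this assay, at which 2 of the 3 values shown sit.

From the compounds shown here alone, it remains open whether the gain on losing fluoro depends on the bromo group. Going by these compounds, it is also open whether chloro, an amine or a carboxylic acid on that same aromatic carbon would match hydrogen or fluoro.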